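Series notes: dipropylamino to diethylamino on the aryloxy core

A few compounds are considered here, and "the series" means these few. Any claim that something is new, unique, unknown or untested is made for them only; others in the source may bear on it.

Three compounds carry values in an assay on HEK293 cells for displacement of a labelled ligand from corticotropin-releasing factor receptor 1 (Homo sapiens), read by scintillation proximity assay, with a stated time of 2 h; on this read-out lower numbers stand for stronger inhibition and higher numbers for weaker inhibition. Compound 1 `CCCN(CCC)c1cccc2nc(Nc3c(OC)cc(COC)cc3OC)c(C)cc12` gives 472 nM. Compound 2 `CCCN(CCC)c1cccc2nc(Nc3c(OC)cc(OC)cc3OC)c(C)cc12` returns only a limit of the assay, > 1000 nM. Within the data shown here, the one measured step, an at least 2.1-fold higher number from compound 1 to compound 2 (0.32 log units; beyond the scatter), is the change from methoxymethyl to methoxy; its size rests on the limit of > 1000 nM in this assay, at which 1 of the 3 values shown sits, and is therefore a lower bound only. Compound 3 `CCCN(CCC)c1cccc2nc(Oc3c(OC)cc(COC)cc3OC)c(C)cc12` gives 138 nM and stands as the lowest of the two numbers available, with compound 1 as the nearest numbered neighbour, beyond the scatter.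

Compound 4 `CCN(CC)c1cccc2nc(Oc3c(OC)cc(COC)cc3OC)c(C)cc12` is not yet measured. It differs from compound 3 in one place: diethylamino in place of dipropylamino on an aromatic carbon. Among the measured compounds shown here, the measured step concerns a substituent on the other aryl ring, not the dialkylamino group, so no measured step bears directly on this change; the amine is the same on compounds 1, 2 and 3, and its shortening has not been tested here. The expectation is therefore anchored on compound 3 with a wider range than the scatter alone would give, and no direction is asserted beyond the scatter. Compound 4 is estimated at 250 nM, in a range from 90 nM to 700 nM, which corresponds to an expected step of a 1.8-fold higher number from compound 3 to compound 4 (0.26 log units; within the scatter).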

Compound 4, half-maximal inhibitory concentration: 70 nM
Compound 4: middle estimate off by 3.6-fold (0.55 log units), on the high side; measured number outside the range, below it.
By their numbers in this assay, from the lowest: compounds 4 and 3 (each within the scatter of the next); then compound 1. At a limit, above all of these: compound 2.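

In this assay the dialkylamino group on the aromatic carbon now has a measured step of its own, a 2.0-fold lower number from compound 3 to compound 4 (0.29 log units; within the scatter) for diethylamino in place of dipropylamino. Among these compounds, earlier comparisons concerned only the substituent on the other aryl ring, whereas this one shows that the position accepts the shorter diethylamino group with no difference beyond the scatter, so on this core the dipropylamino group is not required for compound 4 to read 70 nM in this series. No measurement among those shown explains why the two amines read alike.

On these data alone, the amine position is still defined by only these two closely related groups, so it remains open whether dimethylamino, a longer dibutylamino group or a cyclic amine such as pyrrolidine would stay within the same range. As far as these compounds go, it is also open whether diethylamino reads the same way on the nitrogen-linked core of compound 1, and whether methoxy in place of methoxymethyl has a comparable effect on the oxygen-linked core of compound 4.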